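Swapping a Pyrrolidinylmethyl Arm for a Ring-Bound Amine

This account rests on a few compounds, and the source may have more. Where it says the series, first, only, none or still open, it means among the compounds named here.

Compound 1 `O=C(Nc1nc(-c2ccncc2)c(CN2CCCC2)s1)c1ccncc1` is an amide on a shared core. In an assay on isolated protein for inhibition of Rho-associated protein kinase 2 (Homo sapiens), read by ELISA, with a stated time of 30 min, tested at 10 uM, in the presence of a further agent that is not named here (on this read-out lower numbers stand for less inhibition and higher numbers for more inhibition at the one concentration tested (going by the name of the read-out)), compound 1 gives 47.6%, the highest of the three numbers in hand. Compound 3 `CC(C)N(C)Cc1sc(NC(=O)c2cccnc2)nc1-c1cccnc1` gives 38.1%, within the scatter of compound 1, while compound 2 `CN1CCN(Cc2sc(NC(=O)c3cccnc3)nc2-c2cccnc2)CC1` gives 32.1%, beyond the scatter below compound 1.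

Compound 4 `CC(C)N(C)c1sc(NC(=O)c2ccncc2)nc1-c1ccncc1` has not yet been measured. It differs from compound 1 in one place: isopropyl(methyl)amino in place of (pyrrolidin-1-yl)methyl on an aromatic carbon. The group that leaves holds a five-membered non-aromatic ring; the group that enters has no ring.

Going by the values given here, one measured step bears on this change: a number 6 percentage points higher from compound 2 to compound 3 (within the scatter), where isopropyl(methyl)amino also entered, though there in place of a different group on a saturated chain carbon. That step stayed within the scatter. Among the compounds with values here, in compound 4 the saturated chain carbon is itself gone, and no measured pair tests that, so the range is kept wide. Compound 4 is expected to give 41%, between 22% and 60%. That estimate means a step of a number 6.6 percentage points lower from compound 1 to compound 4 (within the scatter) is expected, nothing beyond the scatter.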

Compound 4, a percentage reported as inhibition, at one concentration (the size of the read-out at that concentration, not a potency): 32.1%
Estimate against measurement, compound 4: 8.9 percentage points above; the measured number falls inside the stated range.
By their numbers in this assay, from the lowest: compounds 2, 4, 3 and 1 (each within the scatter of the next, the first and the last beyond it).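

Putting isopropyl(methyl)amino in place of (pyrrolidin-1-yl)methyl on the aromatic carbon next to the ring sulfur gives, in this assay, a number 15.5 percentage points lower from compound 1 to compound 4 (beyond the scatter). Going by these compounds alone, this is the first one-place step at this position that goes beyond the scatter, whereas the same group entering on a saturated chain carbon gave a number 6 percentage points higher from compound 2 to compound 3 (within the scatter). The change removes the five-membered ring and the chain carbon together, and no information at hand explains the drop.

The compounds shown therefore leave open whether losing the ring or losing the chain carbon matters more. A pyrrolidin-1-yl group set directly on that aromatic carbon would keep the ring without the chain carbon, while a dimethylamino group there would show whether other open-chain amines on this carbon fall in the same range.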